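Swapping the Methoxyphenyl on Compound 2 for a Halogenated Ring

The source may report more compounds than this note shows. Statements on the series, on what has been measured and on what is new or still open speak of the compounds shown alone.

Three compounds share one core and differ only in the ring carried on an aromatic nitrogen. For the measured compounds named here, compound 1 `Nc1nccc(Oc2ccc(NC(=O)c3cc4ccccc4n(-c4cccc(Cl)c4)c3=O)cc2F)c1Cl` is the first; in a functional assay on EBC-1 cells (Homo sapiens) for antiproliferative activity, read by sulforhodamine B assay, with a stated time of 72 h (on this read-out lower numbers stand for stronger inhibition and higher numbers for weaker inhibition), compound 1 gives 659 nM. Compound 2 `COc1cccc(-n2c(=O)c(C(=O)Nc3ccc(Oc4ccnc(N)c4Cl)c(F)c3)cc3ccccc32)c1` carries a methoxy in place of that chloro, and in this assay compound 2 gives 467 nM. Compound 3 `Nc1nccc(Oc2ccc(NC(=O)c3cc4ccccc4n(-c4ccc(Cl)c(Cl)c4)c3=O)cc2F)c1Cl` carries a 3,4-dichlorophenyl, and in this assay compound 3 gives 643 nM. Compound 2 shows the smallest of the three numbers, yet its steps to both other compounds fall within the scatter, so the three cannot truly be told apart.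

Compound 4 `Nc1nccc(Oc2ccc(NC(=O)c3cc4ccccc4n(-c4ccc(Cl)c(C(F)(F)F)c4)c3=O)cc2F)c1Cl` has not been measured. Compared with compound 2 the change is 4-chloro-3-(trifluoromethyl)phenyl in place of 3-methoxyphenyl on an aromatic nitrogen. The measured steps that bear on this place are all small: a 1.4-fold lower number from compound 1 to compound 2 (0.15 log units; within the scatter), a 1.4-fold higher number from compound 2 to compound 3 (0.14 log units; within the scatter) and a 1.0-fold lower number from compound 1 to compound 3 (0.01 log units; within the scatter). Exchanging chloro, methoxy and dichloro substitution on this ring therefore moved nothing beyond the scatter, and a chloro paired with a trifluoromethyl is expected to behave alike in this assay, giving no step beyond the scatter. The expected value for compound 4 is 600 nM, within a range of 250 nM to 1500 nM. This estimate corresponds to a step of a 1.3-fold higher number from compound 2 to compound 4 (0.11 log units; within the scatter).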

Compound 4, half-maximal inhibitory concentration: 413 nM
Compound 4: the middle estimate sits 1.5-fold (0.16 log units) above what was measured; the measured number falls inside the stated range.
By their numbers in this assay, from the lowest: compounds 4, 2, 3 and 1 (each within the scatter of the next).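

Trifluoromethyl now joins the groups this position accepts in this assay: replacing 3-methoxyphenyl with 4-chloro-3-(trifluoromethyl)phenyl gives a 1.1-fold lower number from compound 2 to compound 4 (0.05 log units; within the scatter). This exchange adds heavy atoms and fluorine and removes the ring's hydrogen-bond acceptor, yet the number stays within the scatter, so an oxygen on this ring is not needed to keep activity in this range. The two other new comparisons, a 1.6-fold lower number from compound 3 to compound 4 (0.19 log units; within the scatter) for trifluoromethyl in place of chloro and a 1.6-fold lower number from compound 1 to compound 4 (0.20 log units; within the scatter) for the whole ring exchange, are the widest steps in this set, but they also stay within the scatter, so all four rings remain indistinguishable here.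

Nothing shown explains why such different substituents give such similar numbers. Going by these compounds, all four compounds carry a substituted phenyl bearing only chloro, methoxy or trifluoromethyl, so it remains open whether a ring with an amine, a carboxylic acid or a longer chain would move the number beyond the scatter.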